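A few compounds are considered here, and "the series" means these few. Any claim that something is new, unique, unknown or untested is made for them only; others in the source may bear on it.

The study looks at compounds built on a shared core that carry a nitrile-ended chain, tested in an assay on isolated protein for binding affinity to leukotriene B4 receptor 1 (Homo sapiens), tested at 1 uM; a lower number here means less inhibition, a higher number more inhibition at the concentration tested (going by the name of the read-out). Compound 1, `CCCCc1cc(C(C)=O)c(O)cc1OCCCCC#N`, gives 13% in this assay. Compound 2, `CCc1cc(C(C)=O)c(O)cc1OCCCCCCC#N`, gives 73% in this assay. Among the two measured numbers compound 1 stands lowest; the nearest is compound 2, whose number is higher by a margin beyond the usual scatter. The two differ in more than one place, so their pair shows only that the higher inhibition in this set goes with compound 2.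

The unmeasured compound 3, `CC(=O)c1cc(C=O)c(OCCCCC#N)cc1O`, differs from compound 1 in one place: formyl in place of butyl on an aromatic carbon. Among the measured compounds shown here, no measured pair in this set shows the effect of that change, so the direction it takes is unknown from the data. Everything else of compound 1 stays in place. The step is expected to be small, a number 2 percentage points higher from compound 1 to compound 3 (within the scatter), with no clear direction and probably not beyond the scatter. Compound 3 is therefore estimated at 15% in this assay, within a range from 0% to 45%.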

Compound 3, a percentage reported as inhibition, at one concentration (the size of the read-out at that concentration, not a potency): 3%
Beside the measured number, compound 3's estimate is 12 percentage points above it; measured number inside the range.
By their numbers in this assay, from the lowest: compounds 3 and 1 (each within the scatter of the next); then compound 2.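

In this assay, putting formyl in place of butyl on the aromatic carbon ortho to the 4-cyanobutoxy group gives a number 10 percentage points lower from compound 1 to compound 3 (within the scatter). Among the compounds shown here, this is the first comparison in the set that isolates a single place, and it shows that this exchange, although it swaps a carbon-only chain for a smaller group carrying a hydrogen-bond acceptor, does not separate the two compounds beyond the usual scatter on the core of compound 1. Nothing available explains this result or connects it with any property of either group.

Going by these compounds, it remains open whether an amine, a carboxylic acid or a longer alkyl chain on this aromatic carbon would shift the inhibition beyond the scatter, or whether the same exchange from butyl to formyl would have a larger effect with the nitrile-ended chain of compound 2. Also open, on these data alone, is how much of the gap between compound 1 and compound 2 belongs to the ethyl group on the aromatic carbon and how much to the nitrile-ended chain, as those two compounds differ in more than one place.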